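A few compounds are considered here, and "the series" means these few. Any claim that something is new, unique, unknown or untested is made for them only; others in the source may bear on it.

In a functional assay on MIA PaCa-2 cells (Homo sapiens) for inhibition, read by MTT assay, with a stated time of 72 h, tested at 50 uM (a lower number here means less inhibition of growth, a higher number more inhibition of growth at the concentration tested), compound 1 `C=CCc1cc(O)c(O)c(CN2CCC(C)CC2)c1` gives 90.6%. Compound 2 `C=CCc1ccc(OCc2cn(-c3ccc(C#N)cc3)nn2)c(O)c1` gives 45.9%, and compound 3 `C=CCc1ccc(OCc2cn(-c3cc(OC)c(OC)c(OC)c3)nn2)c(O)c1` gives 49.8%, two values that cannot be separated within the scatter. Compound 2 therefore stands level with compound 3, and the gap up to compound 1 lies beyond the scatter.

Compound 4 `C=CCc1ccc(OCc2cn(-c3ccccc3Cl)nn2)c(O)c1` has not yet been measured. It departs from compound 2 through one change: 2-chlorophenyl in place of 4-cyanophenyl on an aromatic nitrogen. In words, 2-chlorophenyl replaces 4-cyanophenyl on an aromatic nitrogen of the five-membered aromatic ring with 3 nitrogen. For the measured compounds named here, no measured pair isolates this change. Going by the values given here, the only guide is compound 3, which carries a different group at that place and reads 49.8%, close to compound 2. A swap here is thus not expected to move the number far. The expected a number 4.1 percentage points higher from compound 2 to compound 4 (within the scatter) is a small rise that stays within the scatter. The estimate for compound 4 is 50%, with an expected range from 35% to 65%.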

Compound 4, percent growth inhibition at one concentration: 57.7%
For compound 4 the middle estimate is 7.7 percentage points below the measured one, and the stated range covers the measured number.
By their numbers in this assay, from the lowest: compounds 2, 3 and 4 (each within the scatter of the next, the first and the last beyond it); then compound 1.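

In this assay, for the compounds shown here, putting 2-chlorophenyl in place of 4-cyanophenyl on the aromatic nitrogen gives a number 11.8 percentage points higher from compound 2 to compound 4 (beyond the scatter), the first comparison to show that a change at this place can move growth inhibition beyond the scatter, though only modestly. Compound 3, with a third group at the same place, stays within the scatter of both compound 2 and compound 4, so the three groups do not separate into a clean order. No measurement shown here explains the step.

On these data alone, it remains open whether the chlorine itself matters, which a plain phenyl group at this place would help to settle. As far as these compounds go, it is also open whether a saturated group such as cyclohexyl, or a benzyl group, on that nitrogen would hold the inhibition seen with the aryl groups.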